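Swapping the Fluorophenyl for Pyridyl on Compound 2

This account rests on a few compounds, and the source may have more. Where it says the series, first, only, none or still open, it means among the compounds named here.

Compound 2 `CNc1nc(NCc2ccc(NC(=O)c3ccc(F)cc3)cc2)c2ccccc2n1` gives 1600 nM in a functional assay on HCT-116 cells (Homo sapiens) for inhibition, read by luminescence and resazurin assay, with a stated time of 3 days; on this read-out higher numbers stand for weaker inhibition and lower numbers for stronger inhibition. Compound 1 `CNc1nc(NCc2ccc(C(=O)Nc3ccc(F)cc3)cc2)c2ccccc2n1` gives 2900 nM in this assay; the two numbers lie within the usual scatter, as a 1.8-fold lower number from compound 1 to compound 2 (0.26 log units; within the scatter) shows, so compound 2 has the lower of the two numbers without standing apart from compound 1. Compound 3 `CNc1nc(NCc2ccc(NC(=O)c3ccncc3)cc2)c2ccccc2n1` has not yet been measured in this assay. It differs from compound 2 by pyridin-4-yl in place of 4-fluorophenyl on a carbonyl carbon. For the measured compounds named here, the only measured step changes how the amide is joined into the shared core and leaves the 4-fluorophenyl untouched, so it says nothing direct about this exchange, and it was itself small. Going by the values given here, with no measured step bearing on the change, the expected step of a 1.1-fold higher number from compound 2 to compound 3 (0.05 log units; within the scatter) is none beyond the scatter. Compound 3 is therefore estimated at 1800 nM, with a range from 500 nM to 6500 nM.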

Compound 3, half-maximal inhibitory concentration: > 20000 nM
Compound 3: a limit, no number; the forecaster's own chance of this, stated with the estimate: 5%; at least 11-fold (1.04 log units) between middle value and limit.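

Compound 3 carries a limit of the assay rather than a number: the limit of > 20000 nM in this assay, at which 1 of the 3 values shown sits. On this carbonyl carbon, then, the aromatic ring is not interchangeable: pyridin-4-yl in place of 4-fluorophenyl moves the read-out in this assay well beyond the scatter (an at least 12-fold higher number from compound 2 to compound 3 (1.09 log units; beyond the scatter)). The change of how the amide is joined stayed within the scatter, whereas the combined change in both the amide and the ring goes beyond it (an at least 6.8-fold higher number from compound 1 to compound 3 (0.83 log units; beyond the scatter)).

The exchange removes the fluorine and brings in the ring nitrogen together, so the compounds shown cannot separate these two parts. On these data alone, whether a plain phenyl, a 4-chlorophenyl or a pyridin-3-yl on the same carbonyl carbon would stay near compound 2 remains open, as does the effect of pyridin-4-yl on the amide of compound 1.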